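Propyl for cyclopentyl on the amide nitrogen

The source may report more compounds than this note shows. Statements on the series, on what has been measured and on what is new or still open speak of the compounds shown alone.

Three compounds have numbers in a functional assay on K562 cells (Homo sapiens) for antiproliferative activity, read by CCK-8 assay, with a stated time of 72 h; a higher number here means a weaker inhibitor of growth, a lower number a stronger inhibitor of growth. Compound 1 `CC[C@@H]1C(=O)N(C)c2cnc(Nc3ccc(S(=O)(=O)NC4CCCC4)cc3)nc2N1C1CCCC1` gives 872 nM, compound 2 `CCCCNC(=O)c1ccc2c(ccn2-c2ncc3c(n2)N(c2ccn(C)n2)C(CC)C(=O)N3C)c1` gives 14100 nM, and compound 3 `CC[C@@H]1C(=O)N(C)c2cnc(-n3ccc4cc(C(=O)NC5CCCC5)ccc43)nc2N1C1CCCC1` gives 414 nM. Compound 3 has the lowest number of the three; compound 1 stands beyond the scatter above it and compound 2 far beyond. Compound 4 `CCCNC(=O)c1ccc2c(ccn2-c2ncc3c(n2)N(C2CCCC2)[C@H](CC)C(=O)N3C)c1` is not yet measured and differs from compound 3 in one place: propyl in place of cyclopentyl on an amide-type nitrogen. Within the data shown here, no measured pair differs only in this way; compound 2 carries an open-chain amide substituent but also differs from compound 3 elsewhere, so its number is no clean guide. A small loss, near the edge of the scatter, is expected, the estimated step being a 1.7-fold higher number from compound 3 to compound 4 (0.23 log units; within the scatter). Compound 4 is expected to give 700 nM, within 250 nM to 2000 nM.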

Compound 4, concentration for 50% growth inhibition: 395 nM
Compound 4: the middle estimate sits 1.8-fold (0.25 log units) above what was measured; the range from low to high includes it.
By their numbers in this assay, from the lowest: compounds 4 and 3 (each within the scatter of the next); then compound 1; then compound 2.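

In this assay, among these compounds, the step of a 1.0-fold lower number from compound 3 to compound 4 (0.02 log units; within the scatter) is the first clean reading at this amide-type nitrogen. The cyclopentyl ring is not needed here to hold the number: open-chain propyl sits within the scatter of it. This holds for this one pair, on this core, and with the cyclopentyl group left in place on the core's other nitrogen.

Still open, on these data alone, is whether a longer chain such as hexyl, or a chain ending in an amine or a carboxylic acid, would be tolerated on this nitrogen. No evidence on the reason for this tolerance is available.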